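A few compounds are considered here, and "the series" means these few. Any claim that something is new, unique, unknown or untested is made for them only; others in the source may bear on it.

Compound 2 `C#Cc1cn([C@@H]2O[C@H](CO)[C@@H](O)[C@H]2O)c2ncnc(C)c12` stands lowest of the two numbers in an ADME assay on BJ cells (Homo sapiens), read by MTT assay, with a stated time of 72 h (a higher number here means a weaker inhibitor, a lower number a stronger inhibitor), where compound 2 gives 50 nM. Within the data shown here, compound 3 `C#Cc1cn([C@@H]2O[C@H](CO)[C@@H](O)[C@H]2O)c2ncnc(N(C)C)c12` gives 410 nM in this assay; the only measured step, an 8.2-fold higher number from compound 2 to compound 3 (0.91 log units; beyond the scatter), alters a different position and offers no direct guide to the exchange at hand. Compound 1 `O=c1[nH]cnc2c1c(-c1ccoc1)cn2[C@@H]1O[C@H](CO)[C@@H](O)[C@H]1O` gives > 100000 nM in this assay, a limit rather than a number. Compound 4 `Cc1ncnc2c1c(-c1ccoc1)cn2[C@@H]1O[C@H](CO)[C@@H](O)[C@H]1O` differs from compound 2 by furan-3-yl in place of ethynyl on an aromatic carbon. Among the measured compounds shown here, no measured pair isolates this exchange, so the expectation rests on compound 2 alone at 50 nM, with a wide range kept to allow for some loss. Compound 4 is therefore expected to show a 6.0-fold higher number from compound 2 to compound 4 (0.78 log units; beyond the scatter), estimated at about 300 nM, between 50 nM and 2000 nM.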

Compound 4, half-maximal inhibitory concentration: 89200 nM
Compound 4: middle estimate off by 300-fold (2.47 log units), on the low side, outside the stated range (above it).
By their numbers in this assay, from the lowest: compound 2; then compound 3; then compound 4. At a limit, above all of these: compound 1.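

In this assay, furan-3-yl in place of ethynyl on this aromatic carbon gives a 1800-fold higher number from compound 2 to compound 4 (3.25 log units; beyond the scatter). This is much larger than the earlier step on the shared core, an 8.2-fold higher number from compound 2 to compound 3 (0.91 log units; beyond the scatter), so the number depends far more on this exchange than on the dimethylamino one. Compound 1, which also carries furan-3-yl, stands at a limit, not a number: the limit of > 100000 nM in this assay, at which 1 of the 4 values shown sits.

On these data alone, whether the step follows from the entering ring or from the loss of the triple bond stays open. A nitrile or a propynyl group on this carbon would help separate the two.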